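Replacing a Hydroxy Group with Bromine on Compound 3

The compounds below may be only part of what the source reports. "The series", "measured", "known", "first", "only" and "open" are said of these compounds alone.

Measured in a functional assay on A549 cells (Homo sapiens) for antiproliferative activity, read by MTT assay, with a stated time of 72 h; a higher number here means a weaker inhibitor, a lower number a stronger inhibitor:
- compound 1 `O=C(N/N=C/c1cccc(Br)c1)Nc1ccc(Oc2ccnc3[nH]ccc23)c(F)c1` (2220 nM)
- compound 2 `O=C(N/N=C/c1ccc(Br)cc1)Nc1ccc(Oc2ccnc3[nH]ccc23)c(F)c1` (820 nM)
- compound 3 `O=C(N/N=C/c1ccc(O)cc1O)Nc1ccc(Oc2ccnc3[nH]ccc23)c(F)c1` (5840 nM)

Compound 3 has the highest number of the three, making it the weakest inhibitor here. Compound 4 `O=C(N/N=C/c1ccc(O)c(Br)c1)Nc1ccc(Oc2ccnc3[nH]ccc23)c(F)c1` differs from it in one place (3-bromo-4-hydroxyphenyl in place of 2,4-dihydroxyphenyl on a carbon with a double bond to nitrogen), with 3-bromo-4-hydroxyphenyl in place of 2,4-dihydroxyphenyl. Within the data shown here, two measured steps bear on this, and each put 2,4-dihydroxyphenyl in place of a bromophenyl and raised the number (a 2.6-fold higher number from compound 1 to compound 3 (0.42 log units; beyond the scatter)) and (a 7.1-fold higher number from compound 2 to compound 3 (0.85 log units; beyond the scatter)). Moving the bromine also mattered (a 2.7-fold lower number from compound 1 to compound 2 (0.43 log units; beyond the scatter)). A modest step to a lower number is therefore expected in this assay (a 3.2-fold lower number from compound 3 to compound 4 (0.51 log units; beyond the scatter)). Compound 4 is estimated at 1800 nM (expected range 700 nM to 4500 nM).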

Compound 4, half-maximal inhibitory concentration: 9250 nM
Compound 4: the middle estimate sits 5.1-fold (0.71 log units) below what was measured; the measured number lies above the stated range.
By their numbers in this assay, from the lowest: compound 2; then compound 1; then compounds 3 and 4 (each within the scatter of the next).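

In this assay, bromine on the ring does not by itself give a low number: 3-bromo-4-hydroxyphenyl and 2,4-dihydroxyphenyl cannot be told apart (a 1.6-fold higher number from compound 3 to compound 4 (0.20 log units; within the scatter)), while the change from 4-bromophenyl is large (an 11-fold higher number from compound 2 to compound 4 (1.05 log units; beyond the scatter)). Hydroxy in place of hydrogen on an aromatic carbon of the bromophenyl ring also raises the number (a 4.2-fold higher number from compound 1 to compound 4 (0.62 log units; beyond the scatter)), so both hydroxy-bearing compounds sit at the high end. Nothing available gives a reason for this.

Going by these compounds, whether methoxy or an amine in place of the hydroxy of compound 4 would lower the number remains open. So does how chlorine on this ring would compare with bromine.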